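The compounds below may be only part of what the source reports. "The series", "measured", "known", "first", "only" and "open" are said of these compounds alone.

Compound 1 `COc1ccc(NC(=O)[C@@H]2CC=C(CCC=C(C)C)C[C@H]2c2ccccc2)cc1` in an assay on isolated protein for inhibition of Apoptosis regulator Bcl-2 (Homo sapiens), read by fluorescence polarization, with stated times of 5 min and 10 min (a higher number here means a weaker inhibitor, a lower number a stronger inhibitor), gives > 23000 nM, which is a limit of the assay rather than a number. Compound 2 `CC1(C)CCCC2=C1C[C@@H](C(=O)O)[C@H](c1ccccc1)C2` in this assay gives > 23000 nM, again a limit. Compound 3 `CC1(C)CCCC2=C1C[C@H](C(=O)O)[C@@H](c1ccccc1)C2` in this assay gives > 23000 nM, also a limit.

Compound 1 therefore stands nowhere in particular: its own value is only a limit, and the two other values are limits as well (the limit of > 23000 nM in this assay, at which 3 of the 3 values shown sit), so no readable step separates any of these compounds. Compounds 2 and 3 share every atom and bond and differ only in the configuration as drawn (the fact that compounds 2 and 3 differ only in the configuration as drawn). The step that the two limits leave unreadable from compound 2 to compound 3 is one the two limits leave unreadable.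

Compound 4 `CON(C)C(=O)[C@@H]1CC=C(CCC=C(C)C)C[C@H]1c1ccccc1` is the compound still to be measured. It differs from compound 1 in one place: methoxy(methyl)amino in place of (4-methoxyphenyl)amino on a carbonyl carbon. No measured step bears directly on this kind of change; the only step shown concerns configuration and cannot be read. With every measured value sitting at the limit (the limit of > 23000 nM in this assay, at which 3 of the 3 values shown sit), there is no footing for expecting a step out of the limit. The expected step is a step that the limit leaves unreadable from compound 1 to compound 4, which amounts to no readable change. Compound 4 is therefore expected to give about 30000 nM in this assay, within 10000 nM to 100000 nM, most likely reported again only as a limit.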

Compound 4, inhibition constant: > 23000 nM
Compound 4 gave a limit, no number; the forecaster's own chance of this, stated with the estimate: 85%; the middle value is on the limit's open side.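

No size can be given for the change from compound 1 to compound 4, because both results are limits rather than numbers: the limit of > 23000 nM in this assay, at which 4 of the 4 values shown sit. The compounds shown leave open whether methoxy(methyl)amino in place of (4-methoxyphenyl)amino changes inhibition at all, and which structure, if any, would give a real number in this assay.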